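Swapping the Thiazole for a Fluoropiperidine Urea

A few compounds are considered here, and "the series" means these few. Any claim that something is new, unique, unknown or untested is made for them only; others in the source may bear on it.

Measured so far:
- compound 1 `O=C(C1CCC1)N1CCc2nc(C#Cc3ccccc3)sc2C1` gives 370 nM
- compound 2 `O=C(C1CCCCO1)N1CCc2nc(C#Cc3ccccc3)sc2C1` gives only a limit of the assay, > 10000 nM
- compound 3 `Cc1nc(C(=O)N2CCc3nc(C#Cc4ccccc4)sc3C2)cs1` gives only a limit of the assay, > 10000 nM

Going by the values given here, in an assay on HEK293 cells for negative allosteric modulation of metabotropic glutamate receptor 5 (Homo sapiens), read by FLIPR, with a stated time of 1 h (a lower number here means a stronger inhibitor, a higher number a weaker inhibitor), compound 1, which carries a cyclobutyl on the carbonyl carbon, is the one compound with a real number. Compound 3 stands at the weak end of what is shown, resting at the limit of > 10000 nM in this assay, at which 2 of the 3 values shown sit, rather than at a measured value. Replacing the cyclobutyl with oxan-2-yl produced an at least 27-fold higher number from compound 1 to compound 2 (1.43 log units; beyond the scatter), and replacing it with 2-methyl-1,3-thiazol-4-yl produced an at least 27-fold higher number from compound 1 to compound 3 (1.43 log units; beyond the scatter). Between the two limits the comparison is a step that the two limits leave unreadable from compound 2 to compound 3.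

The next change is 4-fluoropiperidin-1-yl in place of 2-methyl-1,3-thiazol-4-yl on a carbonyl carbon, giving compound 4 `O=C(N1CCC(F)CC1)N1CCc2nc(C#Cc3ccccc3)sc2C1`. Among the compounds with values here, the carbonyl carbon now bears a nitrogen-linked ring, a urea-type arrangement that none of the measured compounds contains, so neither measured step directly covers it. Both measured steps show that leaving the cyclobutyl cost potency heavily, which argues against a return to the number of compound 1, yet the limit on compound 3 leaves room for some recovery.

Compound 4 is therefore expected around 2500 nM, within 300 nM to 10000 nM. That estimate means an expected step of an at least 4.0-fold lower number from compound 3 to compound 4 (0.60 log units; beyond the scatter), toward a lower number, with the size uncertain.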

Compound 4, half-maximal inhibitory concentration: > 10000 nM
Compound 4: only a limit was reported; the forecaster's own chance of this, stated with the estimate: 35%; middle value at least 4.0-fold (0.60 log units) from the limit.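

In this assay, the urea-type arrangement with 4-fluoropiperidin-1-yl on the carbonyl carbon gives an at least 27-fold higher number from compound 1 to compound 4 (1.43 log units; beyond the scatter), so a nitrogen-linked ring joins oxan-2-yl and 2-methyl-1,3-thiazol-4-yl as a replacement for cyclobutyl that does not keep a measured potency. The steps among compound 2, compound 3 and compound 4 cannot be read, since each compares one assay limit with another, and no order can be given to these three compounds. Going by these compounds alone, compound 1 remains the only compound with a real number, and the other three compounds, which carry three different kinds of ring at this position, all rest at one assay limit: the limit of > 10000 nM in this assay, at which 3 of the 4 values shown sit.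

The compounds shown leave open how close a group must stay to cyclobutyl to keep a measured potency, for example whether cyclopropyl or cyclopentyl on the carbonyl carbon would give a real number. They also leave open whether a plain piperidin-1-yl without the fluorine, or a smaller azetidin-1-yl, would give a real number in the urea-type arrangement.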